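The source may report more compounds than this note shows. Statements on the series, on what has been measured and on what is new or still open speak of the compounds shown alone.

Of the compounds shown here, two have so far been tested in a functional assay on EL4 cells (Mus musculus) for inhibition, tested at 100 uM; a higher number here means more inhibition at the concentration tested (going by the name of the read-out), a lower number less inhibition. Compound 1 `CSc1[nH]ccc2ncnc1-2` gives < 5% in this assay, which is a limit of the measurement rather than a number (the limit of < 5% in this assay, at which 1 of the 2 values shown sits). Compound 2 `[O-][n+]1ccc2[nH]cnc2c1` gives 5% in this assay. Both results sit at the low end of the scale, so neither compound shows inhibition to speak of at the concentration tested.

Compound 3 `Clc1[nH]ccc2ncnc1-2` differs from compound 1 in one place (chloro in place of methylsulfanyl on an aromatic carbon). Going by the values given here, no measured pair in this set spans such a change, so there is no step to lean on. Given that compound 1 stands at < 5%, the expected movement in this assay is none beyond the usual scatter, and compound 3 is estimated to show 5%, with a range from 0% to 15%. The step that this estimate means, a number no lower from compound 1 to compound 3 (the limit leaves the size open), is expected to stay within the scatter.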

Compound 3, a percentage reported as inhibition, at one concentration (the size of the read-out at that concentration, not a potency): < 5%
Compound 3: only a limit was reported (the forecaster's own chance of this, stated with the estimate: 45%); the middle value lies on the limit itself.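

In this assay compound 3 gives < 5% as a limit of the measurement and not a number. Compound 1 also stands at a limit, so no step can be read between these two compounds: the limit of < 5% in this assay, at which 2 of the 3 values shown sit.

The compounds shown leave open whether any group on this aromatic carbon gives inhibition that can be read as a number.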